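The compounds below may be only part of what the source reports. "The series", "measured", "known", "first", "only" and "open" are said of these compounds alone.

Measured so far:
- compound 1, `COc1ccc(-c2ccnc(C(=O)Nc3ccc(Oc4ccnc5cc(OCCCN6CCN(C)CC6)c(OC)cc45)c(F)c3)c2)cc1`, gives 390 nM in a functional assay on HT-29 cells (Homo sapiens) for cytotoxicity, read by MTT assay, with a stated time of 72 h; a higher number here means a weaker inhibitor, a lower number a stronger inhibitor
- compound 2, `COc1cc2c(Oc3ccc(NC(=O)c4cc(-c5ccccc5F)ccn4)cc3F)ccnc2cc1OCCCN1CCCC1`, gives 230 nM in this assay

Compound 2 holds the lower of the two numbers in this assay, but its gap to compound 1 is within the scatter, so no order between the two can be read from these numbers. Going by the values given here, no single-point step between measured compounds is available.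

Compound 3, `COc1ccc(-c2ccnc(C(=O)Nc3ccc(Oc4ccnc5cc(OCCCN6CCCC6)c(OC)cc45)c(F)c3)c2)cc1`, is not yet measured. It differs from compound 2 in one place: 4-methoxyphenyl in place of 2-fluorophenyl on an aromatic carbon. Beyond that, compound 3 carries the same aryl group as compound 1 while keeping the chain of compound 2, so it joins a feature of each measured compound. The two measured values sit close together, which gives no reason to expect that this change moves the number beyond the scatter in either direction.

For compound 3 the expected result in this assay is 300 nM, with a range of 120 nM to 750 nM. The step this estimate means, a 1.3-fold higher number from compound 2 to compound 3 (0.12 log units; within the scatter), is expected to stay within the scatter, as the two measured values suggest.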

Compound 3, half-maximal inhibitory concentration: 350 nM
Beside the measured number, compound 3's estimate is 1.2-fold (0.07 log units) below it; low and high end bracket the measured number.
By their numbers in this assay, from the lowest: compounds 2, 3 and 1 (each within the scatter of the next).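

Working notes on the series: in this assay the place opposite the ring nitrogen now has its first comparison in which only one group differs, and 4-methoxyphenyl in place of 2-fluorophenyl gives a step that the scatter does not resolve (a 1.5-fold higher number from compound 2 to compound 3 (0.18 log units; within the scatter)). The end of the saturated chain has its first such comparison too, and pyrrolidin-1-yl in place of 4-methylpiperazin-1-yl also stays unresolved (a 1.1-fold lower number from compound 1 to compound 3 (0.05 log units; within the scatter)), so neither exchange separates these compounds in this cytotoxicity read-out. Nothing at hand explains why the numbers lie so close together.

Still open, from the compounds shown here alone, is whether a morpholin-4-yl or dimethylamino group at the chain end, or a longer chain carrying the same pyrrolidin-1-yl, would give a step beyond the scatter. On the aromatic carbon, it also remains open whether an unsubstituted phenyl, a 4-cyanophenyl or a pyridinyl group would separate from the two aryl groups shown here.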